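Compound 1 to compound 4: substituting the amide-type nitrogen

This account rests on a few compounds, and the source may have more. Where it says the series, first, only, none or still open, it means among the compounds named here.

Values in a functional assay (strain AB) with Danio rerio as the target, read by microscopy, with a stated time of 1 h; a higher number here means that more compound is needed for the effect, a lower number that less compound is needed:
- compound 1 `CCN1CCc2c(sc(NC(=O)Nc3ccc(Cl)cc3)c2C(N)=O)C1`: 3120 nM
- compound 2 `NC(=O)c1c(NC(=O)Nc2ccc(Cl)cc2)sc2c1CCN(C1CCOCC1)C2`: 2830 nM
- compound 3 `CCN1CCc2c(sc(NC(=O)Nc3cccc(C#N)c3)c2C(N)=O)C1`: 10300 nM

Compound 1 sits level with compound 2 within the scatter, and compound 3 carries the highest number of the three. Oxan-4-yl in place of ethyl on an amine nitrogen in a ring gave a 1.1-fold lower number from compound 1 to compound 2 (0.04 log units; within the scatter). The change to 3-cyanophenyl in place of 4-chlorophenyl on an amide-type nitrogen gave a 3.3-fold higher number from compound 1 to compound 3 (0.52 log units; beyond the scatter).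

Compound 4 `CCN1CCc2c(sc(NC(=O)Nc3ccc(Cl)cc3)c2C(=O)NC2COC2)C1` keeps the core of compound 1 and differs at one place: oxetan-3-yl in place of hydrogen on an amide-type nitrogen. This turns carbamoyl into (oxetan-3-yl)carbamoyl. For the measured compounds named here, no measured step touches this nitrogen, so both steps bear on it only indirectly, and the direction is weakly grounded. Going by the values given here, the only step beyond the scatter is modest and runs to a higher number, so a modest step the same way is expected, with a wide range.

The expected change in this assay is a 2.2-fold higher number from compound 1 to compound 4 (0.35 log units; beyond the scatter). Compound 4 is estimated at 7000 nM, with an expected range of 2000 nM to 25000 nM.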

Compound 4, half-maximal effective concentration: > 25000 nM
Compound 4: only a limit was reported; the forecaster's own chance of this, stated with the estimate: 15%; middle value at least 3.5-fold (0.55 log units) away from the limit.
By their numbers in this assay, from the lowest: compounds 2 and 1 (each within the scatter of the next); then compound 3. At a limit, above all of these: compound 4.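

In this assay, oxetan-3-yl in place of hydrogen on the amide-type nitrogen gives an at least 8.0-fold higher number from compound 1 to compound 4 (0.90 log units; beyond the scatter), the first step shown at this nitrogen and one that leaves the series with a clear penalty there. The result for compound 4 is a limit of the assay and not a number: the limit of > 25000 nM in this assay, at which 1 of the 4 values shown sits. At the amine nitrogen in a ring, oxan-4-yl in place of ethyl gave a 1.1-fold lower number from compound 1 to compound 2 (0.04 log units; within the scatter), so for these two changes the two nitrogens do not behave alike.

On these data alone, it remains open whether any group on the amide-type nitrogen carries this penalty or oxetan-3-yl in particular, a question that methyl or a 2-hydroxyethyl chain at the same place would address. As far as these compounds go, the full size of the step also stays open, with only its lower bound known.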